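The source may hold more compounds than are shown below. What is called first, only, known or untested is meant among the compounds shown, and "the series" means these compounds.

Compound 1 `COC(=O)[C@@H](NC(=O)CCC(=O)Oc1ccc(C[C@H]2C(=O)OC[C@@H]2Cc2ccc(OC)c(OC)c2)cc1OC)c1c[nH]c2ccccc12` carries an ester side chain ending in an indole on the shared core. In an ADME assay on HeLa cells (Homo sapiens) for cytotoxicity, read by MTT assay (a lower number here means a stronger inhibitor, a higher number a weaker inhibitor), compound 1 returns only a limit of the assay, >= 600000 nM, and not a number. This is the point (the limit of >= 600000 nM in this assay, at which 1 of the 3 values shown sits). Compound 2 `COc1ccc(C[C@H]2COC(=O)[C@@H]2Cc2ccc(OCc3cn(Cc4ccc(F)cc4)nn3)c(OC)c2)cc1OC` gives 198000 nM in this assay, and compound 3 `COc1ccc(C[C@H]2COC(=O)[C@@H]2Cc2ccc(OCc3cn(Cc4ccccc4)nn3)c(OC)c2)cc1OC` gives 346000 nM. For the measured compounds named here, the only step measured between neighbours, a 1.7-fold higher number from compound 2 to compound 3 (0.24 log units; within the scatter), concerns a substituent on the triazole-bearing side chain of compound 2 and compound 3, a part of the molecule that compound 1 does not share, so it does not bear on the change examined here.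

Compound 4 `COC(=O)[C@H](CC(C)C)NC(=O)CCC(=O)Oc1ccc(C[C@H]2C(=O)OC[C@@H]2Cc2ccc(OC)c(OC)c2)cc1OC` keeps the ester side chain of compound 1 and differs from it only in isobutyl in place of 1H-indol-3-yl on a saturated chain carbon bound to an amide-type nitrogen and a carbonyl carbon. Going by the values given here, no measured step touches this part of the molecule, and nothing fixes a direction for the change. With only a limit known for compound 1, compound 4 is expected to stay near it, the step of a number no higher from compound 1 to compound 4 (the limit leaves the size open) being expected to be nil. Compound 4 is expected to give 600000 nM in this assay, within 300000 nM to 1200000 nM, with a limit rather than a number the likelier outcome.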

Compound 4, half-maximal inhibitory concentration: 53200 nM
Compound 4: the middle estimate sits 11-fold (1.05 log units) above what was measured; measured number outside the range, below it.
By their numbers in this assay, from the lowest: compound 4; then compounds 2 and 3 (each within the scatter of the next). At a limit, above all of these: compound 1.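

In this assay, the substituent on the saturated chain carbon bound to an amide-type nitrogen and a carbonyl carbon matters: isobutyl in place of 1H-indol-3-yl gives an at least 11-fold lower number from compound 1 to compound 4 (1.05 log units; beyond the scatter). The size of this step is only a bound, as compound 1 gives a limit of the assay and not a number: the limit of >= 600000 nM in this assay, at which 1 of the 4 values shown sits. For the compounds shown here, the only other step, a 1.7-fold higher number from compound 2 to compound 3 (0.24 log units; within the scatter), lies within the scatter and sits on the triazole-bearing side chain, so the ester side chain is the first part of the series to show a step beyond the scatter.

This single pair does not separate the departure of the 1H-indol-3-yl rings from the entry of isobutyl. On these data alone, how a phenyl, a carboxylic acid or an amine on this saturated chain carbon would read in this assay remains open.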